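Swapping Chloro for Trifluoromethyl in a Small Series

The compounds below may be only part of what the source reports. "The series", "measured", "known", "first", "only" and "open" are said of these compounds alone.

- compound 1 `O=C1C=CC(=O)c2cnccc21` gives 374 nM
- compound 2 `O=C1C(Nc2ccc(F)c(F)c2)=CC(=O)c2ncccc21` gives 251 nM
- compound 3 `O=C1C(Nc2ccc(Cl)cc2)=CC(=O)c2ncccc21` gives 178 nM

All three numbers come from a functional assay (aorta) for inhibition, with Rattus norvegicus as the target; on this read-out higher numbers stand for an effect only at larger amounts of compound and lower numbers for an effect already at smaller amounts. Compound 3 (178 nM) and compound 2 (251 nM) lie within the usual scatter of each other. Compound 1 (374 nM) has a higher number than compound 3, and that gap goes beyond the scatter.

The next compound to be tested is compound 4 `O=C1C(Nc2ccc(C(F)(F)F)cc2)=CC(=O)c2ncccc21` and it has not been measured yet. Compared with compound 3, it has trifluoromethyl in place of chloro on an aromatic carbon, para to a large group (trifluoromethyl in place of chloro on an aromatic carbon). Going by the values given here, no measured pair of compounds shows this change on its own, so the data offer no direct guide. The nearest hint is weak: compound 2 (251 nM) and compound 3 (178 nM) carry different groups and still fall within the scatter of each other. The expected result is therefore no change beyond the scatter, and the estimate is a 1.1-fold higher number from compound 3 to compound 4 (0.05 log units; within the scatter) in this assay and no more than that. For compound 4 the estimated value is 200 nM with an expected range (90 nM to 450 nM).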

Compound 4, half-maximal effective concentration: 607 nM
Compound 4: the middle estimate sits 3.0-fold (0.48 log units) below what was measured; measured number above the stated range.
By their numbers in this assay, from the lowest: compounds 3, 2, 1 and 4 (each within the scatter of the next, the first and the last beyond it).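

In this assay, going by these compounds alone, the group on the aromatic carbon para to a large group now has a direct test, which the earlier compounds could not give, since none of them differed in one place only. Replacing chloro with trifluoromethyl there produces a 3.4-fold higher number from compound 3 to compound 4 (0.53 log units; beyond the scatter), a modest step but one beyond the scatter, so this position does respond to a change of group, and the two groups cannot be treated as interchangeable here. Neither group brings a ring, a hydrogen-bond donor or acceptor, or a net charge, and nothing measured here gives a reason for the step.

This is a single pair, so it leaves open whether a methyl group, a methoxy group or an amine at the same place would give a number close to that of compound 3 or close to that of compound 4. It also leaves open whether the same swap of chloro for trifluoromethyl would give a step of similar size elsewhere on the aromatic ring.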